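From furan to thiophene in a cell toxicity test

The source may hold more compounds than are shown below. What is called first, only, known or untested is meant among the compounds shown, and "the series" means these compounds.

Compound 1 `C=c1[nH]c(=O)/c(=C/c2c[nH]c3ccccc23)[nH]c1=O` gives > 20000 nM
Compound 2 `C=c1[nH]c(=O)/c(=C/c2ccoc2)[nH]c1=O` gives > 20000 nM

In a functional assay on Huh7.5.1 cells (Homo sapiens) for cytotoxicity, read by MTT assay, with a stated time of 72 h (on this read-out lower numbers stand for higher toxicity in this test and higher numbers for lower toxicity in this test), compound 2 gives > 20000 nM as a limit of the assay, not a number. Compound 1 gives > 20000 nM as a limit too. So compound 2 stands at the limit of > 20000 nM in this assay, at which 2 of the 2 values shown sit, and no ranking is possible. Compound 3 `C=c1[nH]c(=O)/c(=C/c2ccsc2)[nH]c1=O` differs by thiophen-3-yl in place of furan-3-yl on a double-bonded chain carbon bound to an aromatic carbon with thiophen-3-yl in place of furan-3-yl on a double-bonded chain carbon bound to an aromatic carbon. Within the data shown here, no measured pair shows such a swap, so no step beyond the scatter is expected in this assay for now. The expected step is a step that the limit leaves unreadable from compound 2 to compound 3 in this estimate. Compound 3 is estimated at 30000 nM with a range from 15000 nM to 60000 nM and will probably be reported only as a limit.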

Compound 3, half-maximal cytotoxic concentration: > 20000 nM
Compound 3: a limit, no number (the forecaster's own chance of this, stated with the estimate: 85%); the middle value is on the limit's open side.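

Compound 2 and compound 3 both end at a limit of the assay rather than a number, so no step can be read between them: the limit of > 20000 nM in this assay, at which 3 of the 3 values shown sit.

In this assay, on these data alone, it stays open whether thiophen-3-yl in place of furan-3-yl changes toxicity at all.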